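From one methylimidazole to another on a shared core

The source may report more compounds than this note shows. Statements on the series, on what has been measured and on what is new or still open speak of the compounds shown alone.

Three compounds share one core. Compound 1 `Cc1cc(Cl)c(-c2ncc[nH]2)cc1NC(=O)c1ccc(OCc2ccccn2)cc1` is reported in a physicochemical assay for lipophilicity (on this read-out higher numbers stand for higher lipophilicity and lower numbers for lower lipophilicity), only as a limit, > 3; this is the limit of > 3 in this assay, at which 1 of the 3 values shown sits. Compound 2 `Cc1cc(Cl)c(-c2cn(C)c(C)n2)cc1NC(=O)c1ccc(OCc2ccccn2)cc1` gives 3.3 in this assay, and compound 3 `Cc1ccc(-c2nccn2C)cc1NC(=O)c1ccc(OCc2ccccn2)cc1` gives 2.8, the lower of the two numbers, set beyond the scatter below compound 2. The step that the limit leaves unreadable from compound 1 to compound 2 is therefore unreadable. Compound 4 `Cc1ccc(-c2cnc(C)n2C)cc1NC(=O)c1ccc(OCc2ccccn2)cc1` differs from compound 3 by one change: 1,2-dimethyl-1H-imidazol-5-yl in place of 1-methyl-1H-imidazol-2-yl on an aromatic carbon. For the measured compounds named here, the only measured step that also alters this ring is that unreadable one, so no measured step sizes the expectation; the entering group carries an added methyl, and a small rise in this assay is expected, a number 0.30 log units higher from compound 3 to compound 4 (within the scatter). For compound 4 the expected value is 3.1, within 2.7 to 3.5.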

Compound 4, distribution coefficient: 2.8
The estimate for compound 4 lay 0.30 log units above the measured number; the measured number falls inside the stated range.
By their numbers in this assay, from the lowest: compounds 3 and 4 (each within the scatter of the next); then compound 2.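

In this assay, 1,2-dimethyl-1H-imidazol-5-yl in place of 1-methyl-1H-imidazol-2-yl gives no change at the digits printed from compound 3 to compound 4 (within the scatter). For the compounds shown here, this is the first readable step for this ring on the carbon para to a methyl group. Going by these compounds alone, the only earlier step that alters the ring cannot be read, since compound 1 is reported only as a limit: the limit of > 3 in this assay, at which 1 of the 4 values shown sits.

Still open, on these data alone, is how 1-methyl-1H-imidazol-5-yl would read at this place, which would separate the added methyl from the changed attachment. Also open, as far as these compounds go, is what an amine or a longer chain on this ring would give.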